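Cytotoxicity of amide-linked biaryl acids and esters

A few compounds are considered here, and "the series" means these few. Any claim that something is new, unique, unknown or untested is made for them only; others in the source may bear on it.

Measured compounds:
compound 1 `CC(C)COc1cccc(-c2ccc(C(=O)N(Cc3cccc(OCCCCCC(=O)O)c3)C(C)C)cc2)c1`, > 26000 nM 
compound 2 `CC(C)N(Cc1cccc(OCCCCCC(=O)O)c1)C(=O)c1ccc(-c2ccoc2)cc1`, > 26000 nM 
compound 3 `CCOC(=O)CCCCCOc1cccc(CN(C(=O)c2ccc(-c3cccc(OCC(C)C)c3)cc2)C(C)C)c1`, > 26000 nM 

In an ADME assay on Raji cells (Homo sapiens) for cytotoxicity, read by CellTiter-Glo and resazurin assay, with a stated time of 72 h (a lower number here means that less compound is needed, a higher number that more compound is needed for the effect), compound 1 reaches only a limit of the assay, > 26000 nM. Compound 2 likewise gives only a limit, > 26000 nM. Compound 3 also gives only a limit, > 26000 nM. The step that the two limits leave unreadable from compound 1 to compound 2 is therefore not readable, and the same holds for a step that the two limits leave unreadable from compound 1 to compound 3. What the three values share is the limit of > 26000 nM in this assay, at which 3 of the 3 values shown sit.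

Compound 4 `CCOC(=O)CCCCCOc1cccc(CN(C(=O)c2ccc(-c3ccoc3)cc2)C(C)C)c1` has not been measured. It differs from compound 3 by furan-3-yl in place of 3-(isobutoxy)phenyl on an aromatic carbon. The same change, (furan-3-yl in place of 3-(isobutoxy)phenyl on an aromatic carbon), is made from compound 1 to compound 2; the two cores differ by ethyl in place of hydrogen on an oxygen next to a carbonyl group.

Going by the values given here, because the limit of > 26000 nM in this assay, at which 3 of the 3 values shown sit, describes every value so far, compound 4 is expected to sit at the limit as well, and the step that the limit leaves unreadable from compound 3 to compound 4 is estimated as flat. The estimate for compound 4 is 40000 nM, between 20000 nM and 120000 nM.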

Compound 4, half-maximal effective concentration: > 26000 nM
Compound 4 gave a limit, no number (the forecaster's own chance of this, stated with the estimate: 90%); the middle value lies beyond the limit too.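

In this assay compound 4 gives > 26000 nM as a limit of the assay, not a number. The steps from compound 3 and from compound 2 to compound 4 cannot be read, and one feature is shared: the limit of > 26000 nM in this assay, at which 4 of the 4 values shown sit. The compounds shown leave open what concentration, if any, would reach the effect, and whether either change alters it.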